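The source may hold more compounds than are shown below. What is called first, only, known or untested is meant among the compounds shown, and "the series" means these compounds.

Measured compounds:
compound 1 `CC[C@H](C)[C@H](N)CN(C(=O)[C@@H]1C[C@H]1c1ccccc1)c1ccc(-c2ccc(C(F)(F)F)cc2)cc1` — in a functional assay for agonist activity at G protein-coupled receptor 88 (Homo sapiens), read by HTRF and cAMP accumulation (on this read-out higher numbers stand for an effect only at larger amounts of compound and lower numbers for an effect already at smaller amounts), compound 1 gives 340 nM
compound 2 `CC[C@H](C)[C@H](N)CN(C(=O)[C@@H]1C[C@H]1c1ccccc1)c1ccc(-c2ccc(Oc3ccccc3)cc2)cc1` — in this assay compound 2 gives 94 nM
compound 3 `CC[C@H](C)[C@H](N)CN(C(=O)[C@@H]1C[C@H]1c1ccccc1)c1ccc(-c2ccc(COC(C)(C)C)cc2)cc1` — in this assay compound 3 gives 280 nM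

Compound 3 sits second highest of the three numbers; its nearest neighbour is compound 1, with a 1.2-fold lower number from compound 1 to compound 3 (0.08 log units; within the scatter), and its furthest is compound 2, with a 3.0-fold higher number from compound 2 to compound 3 (0.47 log units; beyond the scatter).

Compound 4 `CCOC(=O)c1ccc(-c2ccc(N(C[C@@H](N)[C@@H](C)CC)C(=O)[C@@H]3C[C@H]3c3ccccc3)cc2)cc1` differs from compound 3 in one place: ethoxycarbonyl in place of (tert-butoxy)methyl on an aromatic carbon.

Going by the values given here, two measured steps bear on this position. The swap of trifluoromethyl for (tert-butoxy)methyl, a 1.2-fold lower number from compound 1 to compound 3 (0.08 log units; within the scatter), stayed within the scatter; only the phenoxy substituent, a 3.6-fold lower number from compound 1 to compound 2 (0.56 log units; beyond the scatter), moved the number beyond it. Ethoxycarbonyl, like the groups of compound 1 and compound 3, carries no ring, so no step beyond the scatter is expected here, a 1.1-fold higher number from compound 3 to compound 4 (0.03 log units; within the scatter). Compound 4 is therefore estimated at 300 nM, with a range from 120 nM to 750 nM.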

Compound 4, half-maximal effective concentration: 260 nM
Compound 4: the middle estimate sits 1.2-fold (0.06 log units) above what was measured; the measured number falls inside the stated range.
By their numbers in this assay, from the lowest: compound 2; then compounds 4, 3 and 1 (each within the scatter of the next).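

Ethoxycarbonyl, the first group here with a carbonyl, leaves the number level with the two other ringless groups: a 1.1-fold lower number from compound 3 to compound 4 (0.03 log units; within the scatter) and a 1.3-fold lower number from compound 1 to compound 4 (0.12 log units; within the scatter), both within the scatter. Among the four compounds, only phenoxy stands apart, with a 2.8-fold higher number from compound 2 to compound 4 (0.44 log units; beyond the scatter). No measurement here speaks to why these substituents read alike.

Still open, from the compounds shown here alone, is whether the phenoxy gain comes from its ring or its oxygen link, which a benzyl or cyclohexyloxy group would test. A carboxylic acid or an amine at this position also remains unexplored in the compounds shown.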